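This account rests on a few compounds, and the source may have more. Where it says the series, first, only, none or still open, it means among the compounds named here.

Among the measured compounds shown here, compound 3 `COc1ccccc1Nc1cc(C)nc(SCc2nc3ccccc3[nH]2)n1` is the one member of this small set with a numerical result: in a functional assay on ECa-109 cells (Homo sapiens) for cytotoxicity, read by MTT assay, with a stated time of 72 h (on this read-out higher numbers stand for weaker inhibition and lower numbers for stronger inhibition), compound 3 gives 34400 nM. Compound 1 `Cc1cc(N2CCNCC2)nc(SCc2nc3ccccc3[nH]2)n1` reaches only a limit of the assay, > 100000 nM. Compound 2 `Cc1cc(NNC(N)=S)nc(SCc2nc3ccccc3[nH]2)n1` likewise stops at a limit, > 100000 nM. Both of these rest at the limit of > 100000 nM in this assay, at which 2 of the 3 values shown sit. The step of an at least 2.9-fold lower number from compound 1 to compound 3 (0.46 log units; beyond the scatter) and the step of an at least 2.9-fold lower number from compound 2 to compound 3 (0.46 log units; beyond the scatter) can therefore be read only as floors, while a step that the two limits leave unreadable from compound 1 to compound 2 cannot be read at all. Compound 4 `Cc1cc(N(C)Cc2ccccc2)nc(SCc2nc3ccccc3[nH]2)n1` differs from compound 3 by benzyl(methyl)amino in place of (2-methoxyphenyl)amino on an aromatic carbon. For the measured compounds named here, no measured step exchanges one amine of this kind for another, so the step is expected to be small: a 1.2-fold higher number from compound 3 to compound 4 (0.07 log units; within the scatter). Compound 4 is accordingly expected to give 40000 nM, somewhere between 10000 nM and 150000 nM.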

Compound 4, half-maximal inhibitory concentration: > 100000 nM
Compound 4 ended at the assay's limit; the forecaster's own chance of this, stated with the estimate: 35%; middle value at least 2.5-fold (0.39 log units) away from the limit.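

The change from (2-methoxyphenyl)amino to benzyl(methyl)amino brings an at least 2.9-fold higher number from compound 3 to compound 4 (0.46 log units; beyond the scatter) in this assay, although both groups have the same heavy-atom count and one six-membered aromatic ring of carbon only. A group of this size and ring type at this position is therefore not enough to give a numerical result. Compound 3 remains the only compound with one, and the steps among compounds 1, 2 and 4 cannot be read, as these compounds rest at a limit: the limit of > 100000 nM in this assay, at which 3 of the 4 values shown sit.

The two groups differ at once in the methoxy, the methyl on nitrogen and the benzyl link, and the compounds shown leave open which of these counts. They also leave open how a plain phenylamino or a morpholin-4-yl group would read here.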